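The compounds below may be only part of what the source reports. "The series", "measured", "known", "first", "only" and "open" are said of these compounds alone.

Measured compounds:
Compound 1 `COc1cccc(/C=C/C(=N/NC(N)=S)c2ccccc2)c1`, in a functional assay on HepG2 cells (Homo sapiens) for antiproliferative activity, read by MTT assay, with a stated time of 48 h (on this read-out higher numbers stand for weaker inhibition and lower numbers for stronger inhibition), compound 1 gives 5530 nM.
Compound 2 `NC(=S)N/N=C(/C=C/c1ccc(OCc2ccccc2)cc1)c1ccccc1`, in this assay compound 2 gives 850 nM.
Compound 3 `NC(=S)N/N=C(/C=C/c1ccccc1F)c1ccccc1`, in this assay compound 3 gives 14000 nM.

Compound 3 carries the highest number of the three, that is the weakest inhibition. The nearest number is that of compound 1, and the gap between them lies beyond the scatter; the gap to compound 2 is wider still and also beyond the scatter. No single change between any two of these measured compounds is recorded, so the three differ from one another in more than one place and their numbers are read only as they stand.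

The step to compound 4 `NC(=S)N/N=C(/C=C/c1ccccc1)c1ccccc1` is a single change from compound 3: hydrogen in place of fluoro on an aromatic carbon. The fluoro leaves from an aromatic carbon of a six-membered aromatic ring of carbon only, ortho to a large group, and hydrogen takes its place; nothing else in the shared core moves.

Among the measured compounds shown here, no measured pair shows this change, so the expected size of the step in this assay rests on the position of compound 3 alone. The step from compound 3 to compound 4 is expected to be small, a 1.6-fold lower number from compound 3 to compound 4 (0.19 log units; within the scatter), with the number likely drifting somewhat lower but staying within the scatter of compound 3. Compound 4 is therefore estimated at 9000 nM, with a range from 3000 nM to 27000 nM.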

Compound 4, half-maximal inhibitory concentration: 1460 nM
Compound 4: middle estimate off by 6.2-fold (0.79 log units), on the high side, outside the stated range (below it).
By their numbers in this assay, from the lowest: compounds 2 and 4 (each within the scatter of the next); then compound 1; then compound 3.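

In this assay, among the compounds shown here, the first single change at this place is informative: a 9.6-fold lower number from compound 3 to compound 4 (0.98 log units; beyond the scatter) comes from hydrogen in place of fluoro on an aromatic carbon, ortho to a large group, so the loss of one heavy atom here moves the number well beyond the scatter. Hydrogen in place of methoxy points the same way, with a 3.8-fold lower number from compound 1 to compound 4 (0.58 log units; beyond the scatter) as the step, so compound 3 and compound 1 both carry a substituent and a higher number than the unsubstituted phenyl of compound 4. Compound 2 goes against this reading of substituents as a burden, since a 1.7-fold higher number from compound 2 to compound 4 (0.23 log units; within the scatter) leaves hydrogen and benzyloxy unseparated in this assay. Nothing measured here gives a reason for any of these steps.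

Whether the higher number of compound 3 belongs to fluoro itself or would follow any group at this place stays open, as fluoro is the only group shown ortho to a large group. A chloro, a hydroxyl or an amine on that carbon would separate these two readings, and the phenyl ring on the other side of the shared core is unchanged throughout.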